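Cyclopentyloxy in place of hexyloxy on the shared core

The source may report more compounds than this note shows. Statements on the series, on what has been measured and on what is new or still open speak of the compounds shown alone.

The measured compounds and their values:
compound 1, `CC(C(=O)NCc1ccc(C(C)(C)C)cc1N1CCCC1)c1ccc(NS(C)(=O)=O)c(F)c1`, 8.1 nM
compound 2, `CC1CCN(c2cc(C(C)(C)C)ccc2CNC(=O)C(C)c2ccc(NS(C)(=O)=O)c(F)c2)CC1`, 0.7 nM
compound 3, `CCCCCCOc1cc(C(C)(C)C)ccc1CNC(=O)C(C)c1ccc(NS(C)(=O)=O)c(F)c1`, 0.5 nM

All three were tested in an assay on cells for antagonist activity at transient receptor potential cation channel subfamily V member 1 (Homo sapiens), read by FLIPR and calcium flux, with a stated time of 6 min; on this read-out higher numbers stand for weaker inhibition and lower numbers for stronger inhibition. Compound 3 gives the lowest number of the three, but the step of a 1.4-fold lower number from compound 2 to compound 3 (0.15 log units; within the scatter) lies within the scatter, so compounds 2 and 3 cannot be told apart; only compound 1 stands clearly apart, with a 16-fold lower number from compound 1 to compound 3 (1.21 log units; beyond the scatter) and a 12-fold lower number from compound 1 to compound 2 (1.06 log units; beyond the scatter).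

Compound 4, `CC(C(=O)NCc1ccc(C(C)(C)C)cc1OC1CCCC1)c1ccc(NS(C)(=O)=O)c(F)c1`, differs from compound 3 by cyclopentyl in place of hexyl on an oxygen on an aromatic ring. For the measured compounds named here, no measured step bears directly on this exchange: the two large steps both start from the pyrrolidinyl of compound 1, and the one step between the two larger groups was within the scatter. With nothing to suggest a gain, and a shorter group entering, a small loss beyond the scatter is expected, a 3.0-fold higher number from compound 3 to compound 4 (0.48 log units; beyond the scatter). Compound 4 is therefore estimated at 1.5 nM, within 0.4 nM to 6 nM.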

Compound 4, inhibition constant: 1.8 nM
Beside the measured number, compound 4's estimate is 1.2-fold (0.08 log units) below it, and the stated range covers the measured number.
By their numbers in this assay, from the lowest: compounds 3 and 2 (each within the scatter of the next); then compound 4; then compound 1.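

In this assay, the exchange on the oxygen carries a price beyond the scatter (a 3.6-fold higher number from compound 3 to compound 4 (0.56 log units; beyond the scatter)), so keeping the oxygen does not by itself hold the level set by the hexyloxy group. The cyclopentyloxy group also separates from the 4-methylpiperidin-1-yl group (a 2.6-fold higher number from compound 2 to compound 4 (0.41 log units; beyond the scatter)), which the hexyloxy group did not do, yet it keeps a clear advantage over the pyrrolidin-1-yl group (a 4.5-fold lower number from compound 1 to compound 4 (0.65 log units; beyond the scatter)). This gives the position an intermediate level that compounds 1 to 3 did not show, although no measurement offered here explains the difference between the ring and the chain.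

With only one ring and one chain on the oxygen, the compounds shown do not separate the closing of a ring from the loss of a carbon. On these data alone, how a pentyloxy chain or a cyclohexyloxy group would read at this position remains open.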